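This account rests on a few compounds, and the source may have more. Where it says the series, first, only, none or still open, it means among the compounds named here.

Compound 3 `COc1cc2c(Oc3ccc(NC(=O)c4cn(-c5c(C)cccc5C)nn4)cc3F)ccnc2cc1OCCCN1CCCCC1` carries the highest number of the three measured compounds in a functional assay on HT-29 cells (Homo sapiens) for cytotoxicity, read by MTT assay, with a stated time of 72 h (a higher number here means a weaker inhibitor, a lower number a stronger inhibitor), giving 3690 nM. Compound 1 `COc1cc2c(Oc3ccc(NC(=O)c4cn(-c5ccccc5)nn4)cc3F)ccnc2cc1OCCCN1CCCCC1` gives 180 nM in this assay, and compound 2 `COc1cc2c(Oc3ccc(NC(=O)c4cn(-c5ccccc5C)nn4)cc3F)ccnc2cc1OCCCN1CCCCC1` gives 1340 nM. The steps among them run in one direction: a 7.4-fold higher number from compound 1 to compound 2 (0.87 log units; beyond the scatter), a 2.8-fold higher number from compound 2 to compound 3 (0.44 log units; beyond the scatter), and across both changes at once a 21-fold higher number from compound 1 to compound 3 (1.31 log units; beyond the scatter). Each added methyl group on the phenyl ring on the aromatic nitrogen thus raised the number beyond the scatter.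

Compound 4 `COc1cc2c(Oc3ccc(NC(=O)c4cn(-c5c(Cl)cccc5Cl)nn4)cc3F)ccnc2cc1OCCCN1CCCCC1` differs from compound 3 in one place: 2,6-dichlorophenyl in place of 2,6-dimethylphenyl on an aromatic nitrogen. For the measured compounds named here, no measured pair shows a chlorine in place of a methyl, so none of the steps bears on this change directly. Going by the values given here, the steps that do touch the same ring show only that groups at these two positions, added one after the other, weakened compound 2 and compound 3 relative to compound 1. Among the compounds with values here, since the entering group matches the leaving group in its count of heavy atoms and in its two-position pattern, and the data give no step for exchanging one for the other, the expected step is a 1.1-fold lower number from compound 3 to compound 4 (0.02 log units; within the scatter), which is not expected to lie beyond the scatter. Compound 4 is therefore estimated at 3500 nM in this assay, within a range from 1000 nM to 12000 nM.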

Compound 4, half-maximal inhibitory concentration: 240 nM
For compound 4 the middle estimate is 15-fold (1.16 log units) above the measured one; measured number below the stated range.
By their numbers in this assay, from the lowest: compounds 1 and 4 (each within the scatter of the next); then compound 2; then compound 3.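

In this assay the exchange of 2,6-dimethylphenyl for 2,6-dichlorophenyl, which keeps the count of heavy atoms and the two-position pattern, gives a 15-fold lower number from compound 3 to compound 4 (1.19 log units; beyond the scatter) and so shows that the pattern alone does not set the number at this place on the aromatic nitrogen: what stands on the ring matters. For the compounds shown here, the same exchange measured against the single methyl group gives a 5.6-fold lower number from compound 2 to compound 4 (0.75 log units; beyond the scatter) and against the bare phenyl ring gives a 1.3-fold higher number from compound 1 to compound 4 (0.12 log units; within the scatter) so compound 4 goes against the rise seen along compound 1, compound 2 and compound 3, and the two groups at these positions do not act alike. Nothing measured here explains why methyl and chlorine part so widely at this position.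

Going by these compounds alone, whether a single chlorine in the place of the single methyl group of compound 2 would read like compound 2 or like compound 4 remains open. Also open, on these data alone, is how fluorine, methoxy or an amine on this phenyl ring would read in this assay since the four compounds carry only hydrogen, methyl and chlorine there.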